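This account rests on a few compounds, and the source may have more. Where it says the series, first, only, none or still open, it means among the compounds named here.

Measured compounds in an assay on HEK293 cells for displacement of a labelled ligand from growth hormone secretagogue receptor type 1 (Homo sapiens), with a stated time of 60 min; a lower number here means a stronger inhibitor, a higher number a weaker inhibitor:

Compound 1, `CN1CCN(CCCS(=O)(=O)c2ccc3nc(NC(=O)NC(=O)c4cccc(-n5cccn5)c4Cl)sc3c2)CC1`, gives 8.8 nM.
Compound 2, `CN1CCN(CCCS(=O)(=O)c2ccc3nc(NC(=O)NC(=O)c4cc(-n5cccn5)ccc4Cl)sc3c2)CC1`, gives 0.67 nM.
Compound 3, `Cc1cc(C)n(-c2ccc(Cl)c(C(=O)NC(=O)Nc3nc4ccc(S(=O)(=O)CCCN5CCN(C)CC5)cc4s3)c2)n1`, gives 1.3 nM.

Compound 3 stands second highest of these three numbers. Its nearest neighbour is compound 2, and the gap between them, a 1.9-fold higher number from compound 2 to compound 3 (0.29 log units; within the scatter), lies within the usual scatter of repeated measurements. Its furthest neighbour is compound 1, which sits well apart from both, as the step of a 13-fold lower number from compound 1 to compound 2 (1.12 log units; beyond the scatter) shows.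

Compound 4, `CN1CCN(CCCS(=O)(=O)c2ccc3nc(NC(=O)NC(=O)c4cc(-n5cccc5)ccc4Cl)sc3c2)CC1`, has not yet been measured. It differs from compound 3 in one place: 1H-pyrrol-1-yl in place of 3,5-dimethyl-1H-pyrazol-1-yl on an aromatic carbon. Going by the values given here, the measured step that bears on this change is the one from compound 2 to compound 3, where two methyl groups were added to the five-membered ring and the number barely moved. The larger step, from compound 1 to compound 2, concerned where the five-membered ring sits on the six-membered ring and not what that ring is, so it speaks less directly to compound 4. Exchanging one small five-membered aromatic ring for another at the same place is therefore expected to give no step beyond the scatter in this assay, a 1.3-fold lower number from compound 3 to compound 4 (0.11 log units; within the scatter). Compound 4 is estimated at 1 nM, within a range from 0.35 nM to 3 nM.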

Compound 4, half-maximal inhibitory concentration: 0.15 nM
For compound 4 the middle estimate is 6.7-fold (0.82 log units) above the measured one, and the stated range ends above it.
By their numbers in this assay, from the lowest: compound 4; then compounds 2 and 3 (each within the scatter of the next); then compound 1.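

In this assay, compound 2 and compound 3 lie within the scatter of each other, which made the five-membered aromatic ring para to a chloro group look tolerant of change, but the new result shows that the ring's own atoms matter: 1H-pyrrol-1-yl, with one hetero atom, gives a step beyond the scatter both in place of 1H-pyrazol-1-yl (a 4.5-fold lower number from compound 2 to compound 4 (0.65 log units; beyond the scatter)) and in place of 3,5-dimethyl-1H-pyrazol-1-yl (an 8.7-fold lower number from compound 3 to compound 4 (0.94 log units; beyond the scatter)). Among these compounds, then, swapping the ring type counts for more at this position than adding the two methyl groups did. Moving the ring and swapping it together give the widest step of the set (a 59-fold lower number from compound 1 to compound 4 (1.77 log units; beyond the scatter)), and no measurement at hand explains any of these steps.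

From the compounds shown here alone, whether two methyl groups on the 1H-pyrrol-1-yl ring would also stay within the scatter, as they did on the pyrazole ring, remains open. Also open, going by these compounds, is what a phenyl ring, an amine or a carboxylic acid would give at this place, and what 1H-pyrrol-1-yl would give at the ring position found in compound 1.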